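A few compounds are considered here, and "the series" means these few. Any claim that something is new, unique, unknown or untested is made for them only; others in the source may bear on it.

Measured in a functional assay on U-251 cells (Homo sapiens) for antiproliferative activity, read by MTT assay, with a stated time of 72 h; on this read-out lower numbers stand for stronger inhibition and higher numbers for weaker inhibition:
- compound 1 `O=C(Nc1ccc(Cl)c(-c2nnc3c(Cl)cccn23)c1)c1ccc(F)cc1Cl` gives > 100000 nM (a limit of the assay)
- compound 2 `Cc1nc(C(=O)Nc2ccc(Cl)c(-c3nnc4c(Cl)cccn34)c2)cs1` gives 74300 nM
- compound 3 `O=C(Nc1ccc(Cl)c(-c2nnc3c(Cl)cccn23)c1)c1cccnc1` gives > 100000 nM (a limit of the assay)

Compound 1 has no number, only a limit: the limit of > 100000 nM in this assay, at which 2 of the 3 values shown sit.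

Compound 4 `CS(=O)(=O)c1ccc(C(=O)Nc2ccc(Cl)c(-c3nnc4c(Cl)cccn34)c2)cc1` keeps the core of compound 1 and differs in one place (4-(methylsulfonyl)phenyl in place of 2-chloro-4-fluorophenyl on a carbonyl carbon).

Three measured steps at this same place bear on it: an at least 1.3-fold lower number from compound 1 to compound 2 (0.12 log units; that floor lies within the scatter) and an at least 1.3-fold higher number from compound 2 to compound 3 (0.12 log units; that floor lies within the scatter) and a step that the two limits leave unreadable from compound 1 to compound 3. None is shown to go beyond the scatter, so no step beyond the scatter is expected in this assay. The expected step is an at least 1.1-fold lower number from compound 1 to compound 4 (0.04 log units; that floor lies within the scatter). For compound 4 the estimate is 90000 nM (expected range 45000 nM to 150000 nM).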

Compound 4, half-maximal inhibitory concentration: > 100000 nM
Compound 4 ended at the assay's limit (the forecaster's own chance of this, stated with the estimate: 65%); middle value at least 1.1-fold (0.04 log units) away from the limit.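

In this assay, 4-(methylsulfonyl)phenyl, which brings hydrogen-bond acceptors that 2-chloro-4-fluorophenyl lacks, also leaves the value at a limit of the assay and not at a number: the limit of > 100000 nM in this assay, at which 3 of the 4 values shown sit. Among these compounds, the one readable step is an at least 1.3-fold higher number from compound 2 to compound 4 (0.12 log units; that floor lies within the scatter), so this change gives no sign of a real difference at this position. The steps among compound 1, compound 3 and compound 4 cannot be read, as all three values are limits.

From the compounds shown here alone, what an amine or a carboxylic acid on this carbonyl carbon would give stays open. So does whether a change elsewhere on the shared core would bring values clear of the limit.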